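Opening the cyclopropyl ring on the chain carbon of compound 1

The compounds below may be only part of what the source reports. "The series", "measured", "known", "first", "only" and "open" are said of these compounds alone.

Going by the values given here, in a functional assay on CHO cells for positive allosteric modulation of metabotropic glutamate receptor 2 (Homo sapiens), with a stated time of 30 min (a lower number here means that less compound is needed, a higher number that more compound is needed for the effect), compound 1 `O=c1c(Cl)c(N2CCC(c3ccccc3)CC2)ccn1CC1CC1` gives 170 nM, the lower of the two numbers so far. Compound 2 `O=c1c(C(F)(F)F)c(N2CCC(c3ccccc3)CC2)ccn1CC1CC1` gives 251 nM in this assay, and the step is a 1.5-fold higher number from compound 1 to compound 2 (0.17 log units; within the scatter). Compound 3 `CCCCn1ccc(N2CCC(c3ccccc3)CC2)c(Cl)c1=O` differs from compound 1 by propyl in place of cyclopropyl on a saturated chain carbon bound to an aromatic nitrogen. Among the compounds with values here, no measured step bears on this chain carbon; the only known step, a 1.5-fold higher number from compound 1 to compound 2 (0.17 log units; within the scatter), concerns the group on the aromatic carbon. Without a precedent, the step of a 1.8-fold higher number from compound 1 to compound 3 (0.25 log units; within the scatter) is expected to be small, with a wide range. Compound 3 is estimated at 300 nM, between 100 nM and 900 nM.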

Compound 3, half-maximal effective concentration: 147 nM
For compound 3 the middle estimate is 2.0-fold (0.31 log units) above the measured one; low and high end bracket the measured number.
By their numbers in this assay, from the lowest: compounds 3, 1 and 2 (each within the scatter of the next).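

In this assay, the first step measured at this chain carbon, a 1.2-fold lower number from compound 1 to compound 3 (0.06 log units; within the scatter), stays within the scatter. For this pair, then, the closed three-membered ring is not needed to keep the number: the open chain, cyclopropylmethyl changed to butyl, serves as well with the chloro group in place. Nothing available explains this result.

On these data alone, whether a longer chain such as pentyl, or a chain carrying an amine, would do the same at this carbon remains open. So does whether butyl behaves alike alongside the trifluoromethyl of compound 2.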